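Adding a carbonyl to the bridge: expected solubility of compound 4

The source may report more compounds than this note shows. Statements on the series, on what has been measured and on what is new or still open speak of the compounds shown alone.

Of the compounds shown here, three sharing a carboxylic acid tail have been measured in an ADME assay for solubility, read by spectrophotometry, using PAMPA, measured as kinetic solubility, with a stated time of 5 h, at pH 7.4; on this read-out lower numbers stand for lower solubility and higher numbers for higher solubility. Compound 1 `CC(C)(CCCOc1ccc(/C=C/c2ccccc2)cc1)C(=O)O` gives 13 ug/mL. For the measured compounds named here, compound 2 `COc1ccc(/C=C/c2ccc(OCCCC(C)(C)C(=O)O)cc2)cc1`, which carries a methoxy in place of hydrogen on an aromatic carbon, gives 7.32 ug/mL; the step of a 1.8-fold lower number from compound 1 to compound 2 (0.25 log units; within the scatter) is the only one-point change measured so far. Compound 3 `CC(C)(Oc1ccc(CCCOc2ccc(/C=C/c3ccccc3)cc2)cc1)C(=O)O` gives 43.1 ug/mL, the highest of the three numbers, standing beyond the scatter above both compound 1 and compound 2.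

Compound 4 `CC(C)(Oc1ccc(CCCOc2ccc(C(=O)/C=C/c3ccccc3)cc2)cc1)C(=O)O` differs from compound 3 in one place: (2-phenylethenyl)carbonyl in place of 2-phenylethenyl on an aromatic carbon. Going by the values given here, no measured step involves a carbonyl, so the methoxy step from compound 1 to compound 2 bears on it only loosely, as an example of a small added group giving a change within the scatter. A step of similar size in this assay is therefore expected, with no clear direction.

For compound 4 the estimate is 45 ug/mL, within a range from 18 ug/mL to 110 ug/mL, a step of a 1.0-fold higher number from compound 3 to compound 4 (0.02 log units; within the scatter) that is expected to stay near compound 3.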

Compound 4, solubility in the ADME assay: 67.6 ug/mL
Estimate against measurement, compound 4: 1.5-fold (0.18 log units) below; measured number inside the range.
By their numbers in the ADME assay, from the lowest: compounds 2 and 1 (each within the scatter of the next); then compounds 3 and 4 (each within the scatter of the next).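

In the ADME assay, compound 3 gives 43.1 ug/mL and compound 4 gives 67.6 ug/mL; replacing 2-phenylethenyl with (2-phenylethenyl)carbonyl gives a 1.6-fold higher number from compound 3 to compound 4 (0.20 log units; within the scatter) and so shows that this aromatic carbon, para to a large group, can carry a bigger group with one hydrogen-bond acceptor without a change that stands clear of the scatter. In a physicochemical assay for solubility, read by spectrophotometry, in simulated intestinal fluid, at pH 6.5 (a higher number here means a more soluble compound, a lower number a less soluble compound), compound 3 gives 24.8 ug/mL and compound 4 gives 19.6 ug/mL; the same replacement gives a 1.3-fold lower number from compound 3 to compound 4 (0.10 log units; within the scatter) and is also within the scatter, so the two read-outs point the opposite way but agree that the step is small, and neither direction can be trusted. Nothing available explains why this replacement leaves both numbers so little changed.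

From the compounds shown here alone, it remains open whether an amine or an amide at this same place would also stay within the scatter. Going by these compounds, it is equally open whether the carbonyl would give so small a step on the core of compound 1.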